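Thiourea series: 3-cyanophenyl in place of 2-methoxyphenyl

The compounds below may be only part of what the source reports. "The series", "measured", "known", "first", "only" and "open" are said of these compounds alone.

Working notes on three measured compounds and one awaiting measurement. Compound 1 `CCC(C)(C)NC1=NS(=O)(=O)c2cc(Cl)ccc2N1` reports only a limit in a functional assay on U-373MG ATCC cells (Homo sapiens) for inhibition, read by MTT assay, with a stated time of 72 h (on this read-out higher numbers stand for weaker inhibition and lower numbers for stronger inhibition), namely > 100000 nM, which is a limit of the assay and not a number (the limit of > 100000 nM in this assay, at which 1 of the 3 values shown sits). Compound 2 `COc1ccccc1NC(=S)NC1CC(C)(C)Oc2ccc(Br)cc21` gives 22000 nM in this assay. Compound 3 `CC1(C)CC(NC(=O)Nc2ccccc2Cl)c2cc(F)ccc2O1` gives 40000 nM in this assay. Of the two numbers shown, compound 2 and compound 3 sit within the usual scatter of one another, so no order between them is claimed.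

Compound 4 `CC1(C)CC(NC(=S)Nc2cccc(C#N)c2)c2cc(Br)ccc2O1` differs from compound 2 in one place: 3-cyanophenyl in place of 2-methoxyphenyl on an amide-type nitrogen. Among the measured compounds shown here, no pair among the measured compounds isolates a single change, so there is no measured step to lean on. The replacement is expected to give a step of no more than the scatter in this assay, in no particular direction.

Compound 4 is therefore expected at about 22000 nM in this assay, with an estimated range from 8000 nM to 60000 nM. The expected step of no change at the digits printed from compound 2 to compound 4 (within the scatter) is estimated to stay within the scatter.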

Compound 4, half-maximal inhibitory concentration: 6000 nM
Compound 4: the middle estimate sits 3.7-fold (0.56 log units) above what was measured; the measured number lies below the stated range.
By their numbers in this assay, from the lowest: compound 4; then compounds 2 and 3 (each within the scatter of the next). At a limit, above all of these: compound 1.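

In this assay, among the compounds shown here, the aryl group on the amide-type nitrogen of the thiourea gives the first measured single-place step, and it lies beyond the scatter: a 3.7-fold lower number from compound 2 to compound 4 (0.56 log units; beyond the scatter). So this position responds to the change, which the earlier compounds could not show, as no two of them differed in one place only. The two groups match in heavy-atom count and in hydrogen-bond donors and acceptors as counted, and nothing measured here bears on why the number moves.

A single pair cannot separate the loss of the methoxy group from the arrival of the nitrile, or either from where it sits on the phenyl ring. On these data alone, how a plain phenyl, an aminophenyl or a carboxyphenyl would read in this place remains open, as does whether the step carries over to the urea of compound 3.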